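N-Methylation of the piperazine in the kinase series

The compounds below may be only part of what the source reports. "The series", "measured", "known", "first", "only" and "open" are said of these compounds alone.

Compound 1 `CC(O)(C#Cc1cccc(Nc2ncnc3[nH]ccc23)c1)c1nccs1` in an assay for inhibition of mitogen-activated protein kinase kinase kinase 14 (Homo sapiens), read by luminescence and ADP-Glo, with a stated time of 120 min, in the presence of a further agent that is not named here (on this read-out lower numbers stand for stronger inhibition and higher numbers for weaker inhibition), gives 1640 nM. Compound 2 `CC(O)(C#Cc1ccc(N2CCNCC2)c(Nc2ncnc3[nH]ccc23)c1)c1nccs1` in this assay gives 47.9 nM, the lowest of the two numbers in hand; the step of a 34-fold lower number from compound 1 to compound 2 (1.53 log units; beyond the scatter) separates it from compound 1. Compound 3 `CN1CCN(c2ccc(C#CC(C)(O)c3nccs3)cc2Nc2ncnc3[nH]ccc23)CC1` is not yet measured. It differs from compound 2 by methyl in place of hydrogen on an amine nitrogen in a ring. For the measured compounds named here, no measured step bears directly on this change: the single step available, a 34-fold lower number from compound 1 to compound 2 (1.53 log units; beyond the scatter), concerns the entry of the piperazinyl group itself rather than a substituent on its amine nitrogen, and no pair in hand differs by a methyl on such a nitrogen. With nothing to show a shift in either direction, the expected step of a 1.1-fold lower number from compound 2 to compound 3 (0.03 log units; within the scatter) is taken to lie within the scatter. Compound 3 is therefore estimated at 45 nM in this assay, with a range from 15 nM to 150 nM.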

Compound 3, half-maximal inhibitory concentration: 78.3 nM
Compound 3: the middle estimate sits 1.7-fold (0.24 log units) below what was measured; the measured number falls inside the stated range.
By their numbers in this assay, from the lowest: compounds 2 and 3 (each within the scatter of the next); then compound 1.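

In this assay a methyl can take the place of the hydrogen on the amine nitrogen of the piperazine ring with a 1.6-fold higher number from compound 2 to compound 3 (0.21 log units; within the scatter) and no change beyond the scatter, so this nitrogen need not carry a hydrogen to keep the number near that of compound 2. The large step from the unsubstituted core also holds with the methyl in place, as 4-methylpiperazin-1-yl in place of hydrogen on an aromatic carbon gives a 21-fold lower number from compound 1 to compound 3 (1.32 log units; beyond the scatter) in the same range as a 34-fold lower number from compound 1 to compound 2 (1.53 log units; beyond the scatter) for the piperazin-1-yl group. No measurement in hand gives a reason for these steps.

On these data alone, whether a larger group on this nitrogen, such as an ethyl, an acetyl or a hydroxyethyl chain, also stays within the scatter of compound 2 remains open. Also open, as far as these compounds go, is whether the ring is needed at all, or whether an open-chain amine such as dimethylamino on the same aromatic carbon would give a step of similar size from compound 1.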